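Methoxy for Bromo at the Carbonyl Aryl Group

The compounds below may be only part of what the source reports. "The series", "measured", "known", "first", "only" and "open" are said of these compounds alone.

Of the compounds shown here, three built on one shared core have so far been tested in a functional assay on HepG2 cells (Homo sapiens) for cytotoxicity, read by MTT assay, with a stated time of 48 h; a higher number here means a weaker inhibitor, a lower number a stronger inhibitor. Compound 1 `COc1cc(-c2nnc3n2NC(c2ccco2)C(C(=O)c2cccs2)S3)cc(OC)c1OC` gives 64100 nM. Compound 2 `COc1cc(-c2nnc3n2NC(c2ccco2)C(C(=O)c2ccc(F)c(F)c2)S3)cc(OC)c1OC` gives 52400 nM. For compound 3 `COc1cc(-c2nnc3n2NC(c2ccco2)C(C(=O)c2cccc(Br)c2)S3)cc(OC)c1OC` the assay reports no number but only a limit, > 100000 nM. Every change among these three sits on the carbonyl carbon, and none of the steps moved the read-out beyond the usual scatter: a 1.2-fold lower number from compound 1 to compound 2 (0.09 log units; within the scatter), an at least 1.5-fold higher number from compound 1 to compound 3 (0.19 log units; that floor lies within the scatter) and an at least 1.9-fold higher number from compound 2 to compound 3 (0.28 log units; that floor lies within the scatter). Compound 3 therefore stands at the limit of > 100000 nM in this assay, at which 1 of the 3 values shown sits, with no number of its own to place it relative to the other two beyond that floor.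

Compound 4 `COc1cccc(C(=O)C2Sc3nnc(-c4cc(OC)c(OC)c(OC)c4)n3NC2c2ccco2)c1` differs from compound 3 in one place: methoxy in place of bromo on an aromatic carbon. Within the data shown here, the only measured steps that bear on this change are the three exchanges of the group on the carbonyl carbon, and each of them stayed within the scatter. An exchange of bromo for methoxy on the same aromatic ring is expected to behave in the same way, so no step beyond the scatter is expected from compound 3 to compound 4 in this assay, a number no higher from compound 3 to compound 4 (the limit leaves the size open). Compound 4 is estimated at 100000 nM, with a range from 50000 nM to 200000 nM.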

Compound 4, half-maximal inhibitory concentration: > 100000 nM
Compound 4: no number, only a limit (the forecaster's own chance of this, stated with the estimate: 50%); the middle value lies on the limit itself.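

In this assay, the 3-methoxyphenyl group joins the 3-bromophenyl group on the carbonyl carbon in giving only a limit, so a second group at this aromatic position yields no number of its own: the limit of > 100000 nM in this assay, at which 2 of the 4 values shown sit. Set against the other two groups on the carbonyl carbon, the exchange gives an at least 1.9-fold higher number from compound 2 to compound 4 (0.28 log units; that floor lies within the scatter) and an at least 1.5-fold higher number from compound 1 to compound 4 (0.19 log units; that floor lies within the scatter), so neither floor separates compound 4 from the two compounds with numbers. Compound 3 and compound 4 both stand at a limit and the step between them cannot be read, so the new result shows only that methoxy in place of bromo, which brings one hydrogen-bond acceptor where bromo has none, did not return a number in this assay.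

Going by these compounds, how far compound 3 and compound 4 each lie past the limit stays open, and with it any ranking of bromo against methoxy on this aromatic carbon. Also open, on these data alone, is whether an amine, a hydroxyl group or a carboxylic acid on the same aromatic carbon would bring a number back into the range of the assay.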